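The compounds below may be only part of what the source reports. "The series", "measured", "known", "first", "only" and "open" are said of these compounds alone.

Working notes on the para-substituent of the shared core in an ADME assay on THP-1 cells (Homo sapiens) for cytotoxicity; on this read-out lower numbers stand for higher toxicity in this test and higher numbers for lower toxicity in this test.

Three analogues are in hand. Compound 1 `COc1ccc(-n2cc(COc3ccc(/C=N/Nc4nc(-c5ccc(Br)cc5)cs4)cc3)nn2)cc1` gives 35600 nM. Compound 2 `COc1ccc(-n2cc(COc3ccc(/C=N/Nc4nc(-c5ccc([N+](=O)[O-])cc5)cs4)cc3)nn2)cc1` gives 37900 nM. Compound 3 `COc1ccc(-c2csc(N/N=C/c3ccc(OCc4cn(-c5ccc(OC)cc5)nn4)cc3)n2)cc1` gives 39000 nM. Compound 3 holds the highest of the three numbers, but only by steps that are within the scatter: a 1.1-fold higher number from compound 1 to compound 3 (0.04 log units; within the scatter) and a 1.0-fold higher number from compound 2 to compound 3 (0.01 log units; within the scatter). The remaining pair behaves the same way, with a 1.1-fold higher number from compound 1 to compound 2 (0.03 log units; within the scatter). Across bromo, nitro and methoxy at this position, the read-out is effectively flat.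

Compound 4 `COc1ccc(-n2cc(COc3ccc(/C=N/Nc4nc(-c5ccc(Cl)cc5)cs4)cc3)nn2)cc1` is next, differing from compound 3 by chloro in place of methoxy on an aromatic carbon. For the measured compounds named here, the step that bears on it most directly is the one between the halogen-bearing compound 1 and the methoxy-bearing compound 3, which was within the scatter; the nitro-to-methoxy step from compound 2 to compound 3 was likewise within the scatter. Going by the values given here, nothing among the measured compounds suggests that a para halogen moves this read-out. The expected step from compound 3 to compound 4 is therefore a 1.1-fold lower number from compound 3 to compound 4 (0.03 log units; within the scatter), that is, none beyond the scatter. Compound 4 is estimated at 36500 nM, with a range from 24000 nM to 55000 nM.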

Compound 4, half-maximal cytotoxic concentration: 38700 nM
Compound 4: the middle estimate sits 1.1-fold (0.03 log units) below what was measured, and the stated range covers the measured number.
By their numbers in this assay, from the lowest: compounds 1, 2, 4 and 3 (each within the scatter of the next).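

Chloro brings a second halogen and a fourth substituent to this position, and in this assay it sits level with all three earlier groups (a 1.0-fold lower number from compound 3 to compound 4 (0.00 log units; within the scatter); a 1.0-fold higher number from compound 2 to compound 4 (0.01 log units; within the scatter); a 1.1-fold higher number from compound 1 to compound 4 (0.04 log units; within the scatter)). For the compounds shown here, the flat read-out therefore now holds for both halogens as well as for nitro and methoxy, with no compound in the set going against it, and bromo and chloro cannot be told apart on these numbers. The methoxy-to-chloro exchange also removes the oxygen and its hydrogen-bond acceptor without moving the number beyond the scatter, though no available data speak to why this position is so insensitive.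

The compounds shown leave open whether a group of another kind at this position, such as an amine, a carboxylic acid or a longer chain like butoxy, would shift the read-out, or whether plain hydrogen would sit level with the four groups. They also leave open whether the same flatness would hold if the methoxy group elsewhere on the shared core were exchanged, since that part stays constant across all four compounds.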